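Triazole series: replacing the phenyl of compound 1 with pentyl

The source may hold more compounds than are shown below. What is called first, only, known or untested is meant among the compounds shown, and "the series" means these compounds.

Measured so far:
compound 1 `CC(C)=CCC/C(C)=C/Cn1cc(-c2ccccc2)nn1` — 4.91
compound 2 `COC(=O)c1cn(C/C=C(/C)CCC=C(C)C)nn1` — 3.2
compound 3 `CCCCCCCCc1cn(CC=C(C)C)nn1` — 4.92

Three members of the series have been run in a physicochemical assay for lipophilicity, measured as octanol-water partition; a lower number here means a more polar compound, a higher number a more lipophilic compound. Compound 1 gives 4.91, and compound 3 gives 4.92; these two numbers lie within the scatter of each other, so no order between them is claimed. Compound 2 gives 3.2, clearly below both, beyond the scatter. Among the measured compounds shown here, no pair of these three differs in only one place, so no single-point step is available within the measured set.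

Compound 4 `CCCCCc1cn(C/C=C(\C)CCC=C(C)C)nn1` has not been measured. It differs from compound 1 as follows: pentyl in place of phenyl on an aromatic carbon. A pentyl chain in place of the phenyl is expected to move this assay upward by a modest amount, beyond the scatter but not far. Compound 4 is therefore estimated at 5.4, with a range of 4.9 to 5.9. The expected step is a number 0.49 log units higher from compound 1 to compound 4 (beyond the scatter).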

Compound 4, partition coefficient: 5.45
For compound 4 the middle estimate is 0.05 log units below the measured one; low and high end bracket the measured number.
By their numbers in this assay, from the lowest: compound 2; then compounds 1 and 3 (each within the scatter of the next); then compound 4.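

Among the compounds shown here, this is the first comparison that differs in one place only: in this assay, pentyl in place of phenyl on an aromatic carbon gives a number 0.54 log units higher from compound 1 to compound 4 (beyond the scatter), a modest step. The position therefore responds to exchanging a six-membered aromatic ring of carbon for an open chain, even though neither group carries a hydrogen-bond donor or acceptor. No measurement at hand accounts for the size of this step.

Still open, from the compounds shown here alone, is how the number at this position follows chain length, as a longer chain such as octyl on the core of compound 4 would show, and whether a branched chain behaves like pentyl. An amine or a carboxylic acid at the same place would show how far the number can fall from that of compound 4.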